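A few compounds are considered here, and "the series" means these few. Any claim that something is new, unique, unknown or untested is made for them only; others in the source may bear on it.

Working notes on the series.

Of the compounds shown here, two have been measured. Compound 1 `O=C(c1ccc(C(F)(F)F)cc1)N1CCC(NS(=O)(=O)c2cc(S(=O)(=O)c3ccccc3)ccc2C(F)(F)F)CC1` gives 970 nM in an assay on U2OS cells for inhibition of secreted frizzled-related protein 1 (Homo sapiens), read by a luciferase reporter, with a stated time of 18 h; on this read-out lower numbers stand for an effect already at smaller amounts and higher numbers for an effect only at larger amounts of compound. Compound 2 `O=C(O)CCCC(=O)N1CCC(NS(=O)(=O)c2cc(S(=O)(=O)c3ccccc3)ccc2C(F)(F)F)CC1`, which carries 3-carboxypropyl in place of 4-(trifluoromethyl)phenyl on the carbonyl carbon, gives 570 nM in this assay. The step of a 1.7-fold lower number from compound 1 to compound 2 (0.23 log units; within the scatter) is the only one in hand; it falls within the scatter, so compound 2 and compound 1 cannot be told apart on these numbers, and compound 2 merely holds the smaller of the two values.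

Compound 3 `O=C([C@H]1CCNC1)N1CCC(NS(=O)(=O)c2cc(S(=O)(=O)c3ccccc3)ccc2C(F)(F)F)CC1` is not yet measured. Its change from compound 2 is pyrrolidin-3-yl in place of 3-carboxypropyl on a carbonyl carbon. The one step that bears on this position, a 1.7-fold lower number from compound 1 to compound 2 (0.23 log units; within the scatter), exchanged the group on the same carbonyl carbon and produced no movement beyond the scatter, so the carbonyl substituent has so far shown no leverage on this assay. On that basis no step beyond the scatter is expected from compound 2 to compound 3, with the estimated step being a 1.1-fold higher number from compound 2 to compound 3 (0.02 log units; within the scatter). Compound 3 is therefore expected to give about 600 nM in this assay, within a range of 250 nM to 1500 nM.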

Compound 3, half-maximal effective concentration: 700 nM
Beside the measured number, compound 3's estimate is 1.2-fold (0.07 log units) below it; measured number inside the range.
By their numbers in this assay, from the lowest: compounds 2, 3 and 1 (each within the scatter of the next).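

On the carbonyl carbon, pyrrolidin-3-yl now stands as a third group alongside 3-carboxypropyl and 4-(trifluoromethyl)phenyl, and in this assay neither a 1.2-fold higher number from compound 2 to compound 3 (0.09 log units; within the scatter) nor a 1.4-fold lower number from compound 1 to compound 3 (0.14 log units; within the scatter) leaves the scatter. Across these three compounds, then, the position accepts an open chain ending in a carboxylic acid, an aromatic ring carrying trifluoromethyl and a five-membered non-aromatic ring with a ring nitrogen and a defined stereocentre, with no difference that can be read; the flat result from the first pair therefore extends to a group of a quite different kind. No supporting measurement is available that could account for this flat result.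

The compounds shown leave open whether the opposite stereoisomer of pyrrolidin-3-yl, a piperidin-4-yl ring, a tertiary amine, a simple methyl or a longer chain ending in a carboxylic acid on the same carbonyl carbon would move the number beyond the scatter. They also leave open whether any exchange elsewhere on the shared core would do so, as all three compounds differ only on this carbonyl carbon.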